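A few compounds are considered here, and "the series" means these few. Any claim that something is new, unique, unknown or untested is made for them only; others in the source may bear on it.

Of the compounds shown here, three sharing one core have been measured in an in vitro functional assay on cells for agonist activity at Bombesin receptor subtype-3 (Homo sapiens), read by luminescence and calcium flux; a lower number here means that less compound is needed, a higher number that more compound is needed for the effect. Compound 1 `N#Cc1ccc(Cc2cnc(CCc3ccc(-c4ccccc4C(=O)O)cc3)[nH]2)cc1` gives 5890 nM, compound 2 `O=C(O)c1ccccc1-c1ccc(CCc2ncc(CCC3CCCCC3)[nH]2)cc1` gives 642 nM, and compound 3 `O=C(O)c1ccccc1-c1ccc(CCc2ncc(Cc3ccc(F)cc3)[nH]2)cc1` gives 1600 nM. Compound 3 thus stands second highest of the three numbers; its nearest neighbour is compound 2, separated by a 2.5-fold higher number from compound 2 to compound 3 (0.40 log units; beyond the scatter), and furthest from it lies compound 1, separated by a 3.7-fold lower number from compound 1 to compound 3 (0.57 log units; beyond the scatter). The largest movement among the measured compounds is a 9.2-fold lower number from compound 1 to compound 2 (0.96 log units; beyond the scatter).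

Compound 4 `CC(C)(C)c1cnc(CCc2ccc(-c3ccccc3C(=O)O)cc2)[nH]1` is the next compound, differing from compound 3 by tert-butyl in place of 4-fluorobenzyl on an aromatic carbon. Going by the values given here, two measured steps bear on it. a 2.5-fold higher number from compound 2 to compound 3 (0.40 log units; beyond the scatter) shows that replacing a saturated group with a fluorinated aromatic one raised the number modestly, while a 9.2-fold lower number from compound 1 to compound 2 (0.96 log units; beyond the scatter) shows the reverse, a saturated group in place of an aromatic one, lowered it. Both steps are modest, and neither involves a group as small as tert-butyl, so the change to compound 4 is expected to give a small step in this assay, most likely towards a somewhat lower number, not far beyond the scatter. Compound 4 is therefore estimated at 1000 nM, with a range from 300 nM to 3200 nM. The expected step is then a 1.6-fold lower number from compound 3 to compound 4 (0.20 log units; within the scatter).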

Compound 4, half-maximal effective concentration: 4330 nM
Beside the measured number, compound 4's estimate is 4.3-fold (0.64 log units) below it; the whole stated range lies below it.
By their numbers in this assay, from the lowest: compound 2; then compound 3; then compounds 4 and 1 (each within the scatter of the next).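

In this assay, going by these compounds alone, the earlier compounds had compared only groups carrying a ring at this aromatic carbon of the five-membered ring. Tert-butyl, with no ring and 4 heavy atoms against the 8 of 4-fluorobenzyl, shows that a smaller group without a ring does not bring a lower number here: there is a 2.7-fold higher number from compound 3 to compound 4 (0.43 log units; beyond the scatter), and against 2-cyclohexylethyl there is a 6.7-fold higher number from compound 2 to compound 4 (0.83 log units; beyond the scatter). Size alone does not order these groups, however, and compound 1 goes against any such reading: a 1.4-fold lower number from compound 1 to compound 4 (0.13 log units; within the scatter) leaves tert-butyl within the scatter of 4-cyanobenzyl, although that group is the larger one and carries a ring. Nothing among the data shown explains these differences.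

Open, as far as these compounds go, is how an amine, a carboxylic acid or a smaller group such as methyl would fare at this aromatic carbon, and whether a longer chain ending in a phenyl ring would match 2-cyclohexylethyl. Also open, from the compounds shown here alone, is whether the saturated ring or the length of the chain sets compound 2 apart, since 2-cyclohexylethyl differs from both benzyl groups in these two features at once.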